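The source may report more compounds than this note shows. Statements on the series, on what has been measured and on what is new or still open speak of the compounds shown alone.

Of the compounds shown here, three sharing one core have been measured in a functional assay on cells (Platelet, Homo sapiens) for inhibition; on this read-out higher numbers stand for weaker inhibition and lower numbers for stronger inhibition. Compound 1 `CCOC(=O)c1ccc(-c2nn(Cc3ccc(F)cc3)c3ccccc23)cc1` gives 190 nM, compound 2 `CCOC(=O)c1ccc(-c2nn(Cc3cccc(OC)c3)c3ccccc23)cc1` gives 260 nM, and compound 3 `CCOC(=O)c1ccc(-c2nn(-c3ccco3)c3ccccc23)cc1` gives 340 nM. Compound 3 cannot be separated from the other two, since a 1.8-fold higher number from compound 1 to compound 3 (0.25 log units; within the scatter) and a 1.3-fold higher number from compound 2 to compound 3 (0.12 log units; within the scatter). Still unmeasured is compound 4 `CCOC(=O)c1ccc(-c2nn(C(C)C)c3ccccc23)cc1`, which differs from compound 3 by one change: isopropyl in place of furan-2-yl on an aromatic nitrogen. In words, this is isopropyl in place of furan-2-yl on an aromatic nitrogen. The measured steps all altered the group carried by this nitrogen, and the third of them, a 1.4-fold higher number from compound 1 to compound 2 (0.14 log units; within the scatter), also stayed small. None of the three left the scatter, so no step beyond the scatter is expected in this assay. On these data alone, every measured group there contains a ring, however, so an isopropyl group without one remains untested and the range must stay wide. The expected step is a 1.1-fold lower number from compound 3 to compound 4 (0.05 log units; within the scatter), with no firm direction. For compound 4 the estimated value is 300 nM, with an expected range from 110 nM to 900 nM.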

Compound 4, half-maximal inhibitory concentration: 650 nM
Estimate against measurement, compound 4: 2.2-fold (0.34 log units) below, and the stated range covers the measured number.
By their numbers in this assay, from the lowest: compounds 1, 2, 3 and 4 (each within the scatter of the next, the first and the last beyond it).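

Among the compounds shown here, in (this assay), the isopropyl group of compound 4 is the only group on this aromatic nitrogen without a ring, and it gives the first steps beyond the scatter at this position, both modest and both replacing a substituted benzyl group (a 2.5-fold higher number from compound 2 to compound 4 (0.40 log units; beyond the scatter)) (a 3.4-fold higher number from compound 1 to compound 4 (0.53 log units; beyond the scatter)). Against the furan-2-yl group the same change stays within the scatter (a 1.9-fold higher number from compound 3 to compound 4 (0.28 log units; within the scatter)), so compound 3 goes against any simple split between groups with and without a ring. No measurement shown offers an explanation for these steps.

Isopropyl differs from the benzyl groups both in having no ring and in its heavy atom count, and the compounds shown do not separate the two. A cyclopentyl group or a longer chain such as n-butyl on this nitrogen would bear on that question.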